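The source may hold more compounds than are shown below. What is called first, only, known or untested is meant among the compounds shown, and "the series" means these compounds.

Working notes on the series. Compound 1 `CSc1cc(C)nc(SC)c1NC(=O)N(Cc1ccccc1)Cc1cccc(-c2cc[nH]n2)c1` carries the shared core with an unsubstituted benzyl group on the urea nitrogen. In a functional assay on a cell-free system (plasma) with sterol O-acyltransferase, Soat (Rattus norvegicus) as the target (a lower number here means that less compound is needed, a higher number that more compound is needed for the effect), compound 1 gives 0.046 mg/kg. Compound 2 `CSc1cc(C)nc(SC)c1NC(=O)N(Cc1ccc(N(C)C)cc1)Cc1cccc(-c2cc[nH]n2)c1` bears a dimethylamino group on that benzyl group. In this assay compound 2 gives only a limit, < 0.1 mg/kg, and no number stands for it. The step that the limit leaves unreadable from compound 1 to compound 2 is therefore not readable in size; it rests on (the limit of < 0.1 mg/kg in this assay, at which 1 of the 2 values shown sits). Compound 3 `CSc1cc(C)nc(SC)c1NC(=O)N(Cc1ccc(F)cc1)Cc1cccc(-c2cc[nH]n2)c1` is the next member, still to be measured in this assay. Relative to compound 2 the change is fluoro in place of dimethylamino on an aromatic carbon. Among the measured compounds shown here, no measured step speaks directly to this exchange: the single step on record is unreadable and concerns dimethylamino against hydrogen, not fluoro. What is known is that compound 1 sits at its measured value and that compound 2 lies under the limit, both in the same low region. A step within the scatter is therefore expected for a step that the limit leaves unreadable from compound 2 to compound 3. For compound 3 the estimated value is 0.05 mg/kg, with an expected range from 0.02 mg/kg to 0.15 mg/kg.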

Compound 3, dose for half-maximal effect: < 0.1 mg/kg
Compound 3: a limit, no number; the forecaster's own chance of this, stated with the estimate: 30%; the middle value lies beyond the limit too.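

In this assay compound 3 gives only a limit, < 0.1 mg/kg. No step among compound 1, compound 2 and compound 3 can be read in size, and this rests on one line: the limit of < 0.1 mg/kg in this assay, at which 2 of the 3 values shown sit.

The compounds shown leave open where compound 2 and compound 3 lie relative to compound 1 and to each other in this assay.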